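This account rests on a few compounds, and the source may have more. Where it says the series, first, only, none or still open, it means among the compounds named here.

Of the compounds shown here, three sharing one core have been measured in an assay on HEK293 cells for inhibition of Steryl-sulfatase (Homo sapiens), tested at 0.1 uM; on this read-out lower numbers stand for a weaker effect and higher numbers for a stronger effect at the one concentration tested. Compound 1 `CCN(Cc1ccccc1)c1cccc(C(=O)N2CCc3ccc(OS(N)(=O)=O)cc3C2)c1` gives 17.3% in this assay. Compound 2 `NS(=O)(=O)Oc1ccc2c(c1)CN(C(=O)c1cccc(N(Cc3ccccc3)Cc3ccco3)c1)CC2` gives 27.5%, and compound 3 `CN(C)CCCN(Cc1ccccc1)c1cccc(C(=O)N2CCc3ccc(OS(N)(=O)=O)cc3C2)c1` gives 23.8%. Compound 3 stands second highest of the three numbers: its nearest neighbour is compound 2, and its furthest is compound 1, and both of those gaps lie within the scatter. Among the compounds with values here, the only step beyond the scatter is a number 10.2 percentage points higher from compound 1 to compound 2 (beyond the scatter), which concerns a furan-2-yl in place of methyl. The steps that touch the chain carrying the dimethylamino group were a number 6.5 percentage points higher from compound 1 to compound 3 (within the scatter) and a number 3.7 percentage points lower from compound 2 to compound 3 (within the scatter), neither of them beyond the scatter.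

Compound 4 `CN(C)CCN(Cc1ccccc1)c1cccc(C(=O)N2CCc3ccc(OS(N)(=O)=O)cc3C2)c1` differs from compound 3 in one place: dimethylamino in place of (dimethylamino)methyl on a saturated chain carbon, two bonds along the chain from a nitrogen on an aromatic ring. Read one bond further out, the chain goes from 3-(dimethylamino)propyl to 2-(dimethylamino)ethyl. Since adding the (dimethylamino)methyl in compound 3 moved the number only within the scatter, removing one link again is expected to give no step beyond the scatter. The step from compound 3 to compound 4 is therefore estimated as a number 1.8 percentage points lower from compound 3 to compound 4 (within the scatter). Compound 4 is expected to give 22% in this assay, within a range from 10% to 35%.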

Compound 4, a percentage reported as inhibition, at one concentration (the size of the read-out at that concentration, not a potency): 0%
Compound 4: the middle estimate sits 22 percentage points above what was measured; measured number below the stated range.
By their numbers in this assay, from the lowest: compound 4; then compounds 1, 3 and 2 (each within the scatter of the next, the first and the last beyond it).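

In this assay, within the data shown here, the change from 3-(dimethylamino)propyl to 2-(dimethylamino)ethyl comes with a number 23.8 percentage points lower from compound 3 to compound 4 (beyond the scatter) and is the first change at this position to carry the number down beyond the scatter, so the dimethylamino group cannot be judged apart from the length of the chain that holds it. Placed on the saturated chain carbon two bonds along from the nitrogen on the aromatic ring, dimethylamino gives a number 17.3 percentage points lower from compound 1 to compound 4 (beyond the scatter) while (dimethylamino)methyl at that same place left compound 3 within the scatter of compound 1, and the comparison with the furan-2-yl compound gives a number 27.5 percentage points lower from compound 2 to compound 4 (beyond the scatter) so that compound 4 stands lowest of the four. Nothing available accounts for this loss.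

The compounds shown leave open whether a longer chain such as 4-(dimethylamino)butyl holds the number seen for the 3-(dimethylamino)propyl chain. They also leave open whether the loss on the 2-(dimethylamino)ethyl chain belongs to the dimethylamino group itself or would also follow with a pyrrolidine, a primary amine or a hydroxyl at the end of that chain.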